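Chlorophenyl for chlorothiophenyl on the sulfonyl sulfur

A few compounds are considered here, and "the series" means these few. Any claim that something is new, unique, unknown or untested is made for them only; others in the source may bear on it.

Compound 1 `O=S(=O)(Nc1ccc(-c2nc3ccccc3o2)cc1)c1ccc(Cl)s1` sits at the limit of an assay on isolated protein for inhibition of malate dehydrogenase, mitochondrial (Sus scrofa), with stated times of 45 min and 30 min (a higher number here means a weaker inhibitor, a lower number a stronger inhibitor), giving > 63000 nM, a limit rather than a number. Compound 2 `COc1ccccc1S(=O)(=O)Nc1ccc2oc(-c3ccccc3)nc2c1` also gives only a limit, > 63000 nM. Compound 3 `COc1ccc(Cl)cc1S(=O)(=O)Nc1ccc2oc(-c3ccccc3)nc2c1` likewise gives a limit, > 63000 nM. Among the compounds with values here, the one step between measured compounds, a step that the two limits leave unreadable from compound 2 to compound 3, cannot be read, and it concerns a chloro on an aromatic carbon rather than the group on the sulfonyl sulfur. Compound 4 `O=S(=O)(Nc1ccc(-c2nc3ccccc3o2)cc1)c1ccc(Cl)cc1` differs from compound 1 by 4-chlorophenyl in place of 5-chlorothiophen-2-yl on a sulfonyl sulfur. Within the data shown here, no measured step bears on this change; what is known is the limit of > 63000 nM in this assay, at which 3 of the 3 values shown sit. The expectation for compound 4 is therefore a value at the limit of this assay, with the step that the limit leaves unreadable from compound 1 to compound 4 expected to remain unreadable. Compound 4 is estimated at 100000 nM, range 30000 nM to 400000 nM.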

Compound 4, half-maximal inhibitory concentration: > 63000 nM
Compound 4 ended at the assay's limit (the forecaster's own chance of this, stated with the estimate: 85%); the middle value is on the limit's open side.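

In this assay, compound 1 and compound 4 both give a limit rather than a number, so no step can be read between them: the limit of > 63000 nM in this assay, at which 4 of the 4 values shown sit.

The compounds shown leave open which structural change, if any, would give a readable value.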